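Swapping the aryl ketone substituent in three HDAC6 inhibitors

The compounds below may be only part of what the source reports. "The series", "measured", "known", "first", "only" and "open" are said of these compounds alone.

Of the compounds shown here, three have been measured in an assay on isolated protein for inhibition of protein deacetylase HDAC6 (Homo sapiens); a higher number here means a weaker inhibitor, a lower number a stronger inhibitor. Compound 1 `COc1cccc(C(=O)c2ccc3c(ccn3S(=O)(=O)c3cccc(/C=C/C(=O)NO)c3)c2)c1` gives 1810 nM, and compound 2 `Cc1ccc(C(=O)c2ccc3c(ccn3S(=O)(=O)c3cccc(/C=C/C(=O)NO)c3)c2)cc1` gives 2750 nM. These two share a core and differ only by 3-methoxyphenyl in place of 4-methylphenyl on a carbonyl carbon, a change that made a 1.5-fold lower number from compound 2 to compound 1 (0.18 log units; within the scatter). Compound 3 `Cc1ccc(C(=O)c2ccc3c(ccn3Cc3ccc(C(=O)NO)cc3)c2)cc1` gives 11.9 nM in this assay, the lowest of the three numbers and well apart from the other two; the difference between its core and the core of compound 2 is not broken down here. Compound 4 `COc1cccc(C(=O)c2ccc3c(ccn3Cc3ccc(C(=O)NO)cc3)c2)c1` carries the same change on the core of compound 3, namely (3-methoxyphenyl in place of 4-methylphenyl on a carbonyl carbon), and the surroundings of the place are the same in both pairs. Because the earlier change made a 1.5-fold lower number from compound 2 to compound 1 (0.18 log units; within the scatter), a step within the scatter, the step expected from compound 3 to compound 4 in this assay is a 1.3-fold lower number from compound 3 to compound 4 (0.10 log units; within the scatter), of the same modest size. Compound 4 is therefore estimated at 9.5 nM, with a likely range from 4 nM to 25 nM.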

Compound 4, half-maximal inhibitory concentration: 16.4 nM
For compound 4 the middle estimate is 1.7-fold (0.24 log units) below the measured one; low and high end bracket the measured number.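

In this assay, placing 3-methoxyphenyl in place of 4-methylphenyl on a carbonyl carbon gives a 1.4-fold higher number from compound 3 to compound 4 (0.14 log units; within the scatter) on the core of compound 3, and set beside the step on the other core, the result gives no sign that the change behaves differently between the two: the same change on two cores in this assay, a 1.5-fold lower number (0.18 log units; within the scatter) from compound 2 to compound 1 and a 1.4-fold higher number (0.14 log units; within the scatter) from compound 3 to compound 4, 2.1-fold (0.32 log units) apart, within the scatter of two such steps. On both cores, the step is too small to separate from the scatter, so the two pairs agree only in that neither shows a clear effect of this swap. They do not show that the change has a real effect of either direction, and two pairs cannot establish that it would stay this small on other cores in the series.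

The compounds shown leave open whether a different group on the carbonyl carbon, such as an amine, a carboxylic acid or a longer chain, would give a step beyond the scatter on either core. They also leave open which single part of the core accounts for the gap between the two pairs, as no step that differs in one place links them.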